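A larger group on the carbonyl carbon of compound 2

The source may report more compounds than this note shows. Statements on the series, on what has been measured and on what is new or still open speak of the compounds shown alone.

Measured so far in a functional assay on HT-29 cells (Homo sapiens) for antiproliferative activity, read by sulforhodamine B assay, with a stated time of 48 h; a higher number here means a weaker inhibitor, a lower number a stronger inhibitor:
compound 1 `CC(C)c1ccccc1OS(=O)(=O)c1cccc(NC(=O)CCl)c1`: 4500 nM
compound 2 `CC(=O)Nc1ccc(S(=O)(=O)Oc2ccccc2I)cc1`: 23000 nM

Of these two numbers, compound 2 holds the higher one, so it is the weaker inhibitor of the pair, and the gap to compound 1 lies beyond the usual scatter of this kind of measurement. Compound 3 `O=C(NCC1CCCC1)Nc1ccc(S(=O)(=O)Oc2ccccc2I)cc1` keeps the core of compound 2 and changes a single place: (cyclopentylmethyl)amino in place of methyl on a carbonyl carbon. For the measured compounds named here, no measured pair here shows what this kind of change does, so only a modest step is expected, a 1.5-fold lower number from compound 2 to compound 3 (0.19 log units; within the scatter), toward a lower number. Compound 3 is therefore expected to give about 15000 nM, most likely between 4000 nM and 50000 nM.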

Compound 3, half-maximal inhibitory concentration: 7600 nM
Compound 3: the middle estimate sits 2.0-fold (0.30 log units) above what was measured, and the stated range covers the measured number.
By their numbers in this assay, from the lowest: compounds 1 and 3 (each within the scatter of the next); then compound 2.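

The carbonyl carbon of compound 2 is open to a far larger group than methyl: in this assay, (cyclopentylmethyl)amino gives a 3.0-fold lower number from compound 2 to compound 3 (0.48 log units; beyond the scatter) and so brings a real gain rather than a loss. For the compounds shown here, this is the first sign that this position can take a five-membered ring and an added hydrogen-bond donor. Nothing available explains the gain.

As far as these compounds go, it remains open whether the ring or the new nitrogen matters more. A methylamino group or a cyclopentylmethyl group without that nitrogen, on the same carbonyl carbon, would separate the two.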